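A few compounds are considered here, and "the series" means these few. Any claim that something is new, unique, unknown or untested is made for them only; others in the source may bear on it.

Among the compounds with values here, compound 1 `C=C(Br)C(=O)Nc1cccc(-c2cn3nc(-c4ccccc4)sc3n2)c1` gives 900 nM in a functional assay on FM3A cells (Mus musculus) for inhibition, read by cell counting, with a stated time of 2 days (on this read-out higher numbers stand for weaker inhibition and lower numbers for stronger inhibition), the lower of the two numbers so far. Compound 2 `Nc1cccc(-c2cn3c(-c4ccc(Cl)cc4)csc3n2)c1`, built on a different core, gives 11000 nM in this assay, a gap beyond the scatter. Compound 3 `C=C(Br)C(=O)Nc1cccc(-c2cn3nc(-c4cccs4)sc3n2)c1` is the unmeasured analogue of compound 1 carrying (thiophen-2-yl in place of phenyl on an aromatic carbon). Within the data shown here, no measured pair tests this exchange, so the expectation rests on compound 1 alone. For compound 3 the expected step is no change at the digits printed from compound 1 to compound 3 (within the scatter), none beyond the scatter in either direction. Compound 3 is therefore estimated at 900 nM, within 300 nM to 2700 nM.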

Compound 3, half-maximal inhibitory concentration: 370 nM
Beside the measured number, compound 3's estimate is 2.4-fold (0.39 log units) above it; the range from low to high includes it.
By their numbers in this assay, from the lowest: compound 3; then compound 1; then compound 2.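

In this assay, thiophen-2-yl in place of phenyl on this aromatic carbon gives a 2.4-fold lower number from compound 1 to compound 3 (0.39 log units; beyond the scatter), a modest step. Within the data shown here, this is the first sign that the position responds to the aromatic ring it carries, and that phenyl is not required there for inhibition at this level. No data at hand account for the step.

Still open, as far as these compounds go, is whether pyridin-2-yl, an amine or a longer alkyl chain on this carbon would keep or lower the number. Also open, from the compounds shown here alone, is whether the same exchange would give a similar step on the core of compound 2.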